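A few compounds are considered here, and "the series" means these few. Any claim that something is new, unique, unknown or untested is made for them only; others in the source may bear on it.

Working notes on the series, read in a physicochemical assay for lipophilicity, at pH 7.4; on this read-out higher numbers stand for higher lipophilicity and lower numbers for lower lipophilicity. Within the data shown here, only two compounds have a number so far. Compound 1 (`CCC(=O)N1C[C@@H]2[C@H](C1)[C@H]2NC(=O)c1cc(C(=O)NC)c2c(c1)[C@H](c1ccccc1)CO2`) gives 3.4, the lower of the two, and compound 2 (`CNC(=O)c1cc(C(=O)N[C@H]2C[C@@H]2C)cc2c1OC[C@@]2(C)c1ccccc1`) gives 4.7, a gap beyond the usual scatter. Compound 3 (`CNC(=O)c1cc(C(=O)N[C@H]2C[C@@H]2C)cc2c1OC[C@H]2c1ccccc1`) has not been measured.

The step from compound 1 to compound 3 is a single exchange on an amide-type nitrogen whose other neighbours are: carbonyl carbon. In counted terms it reads (a group of 4 heavy atoms (4 carbon; one three-membered non-aromatic ring of carbon only) in place of a group of 10 heavy atoms (8 carbon, 1 nitrogen, 1 oxygen; one three-membered non-aromatic ring of carbon only, one five-membered non-aromatic ring with 1 hetero atom), on an amide-type nitrogen). Among the measured compounds shown here, no measured step between closely matched compounds exists yet, so the expectation rests on two values alone. Compound 2 also carries 2-methylcyclopropyl on an amide-type nitrogen and stands at 4.7, which points to a clear rise in this assay rather than a shift within the scatter. The expected change, a number 0.90 log units higher from compound 1 to compound 3 (beyond the scatter), is upward and beyond the scatter, though this is an estimate without a direct precedent. For compound 3 the estimated value is 4.3, with an expected range from 3.8 to 4.7.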

Compound 3, distribution coefficient: 4.5
Compound 3: middle estimate off by 0.20 log units, on the low side, within the range that was stated.
By their numbers in this assay, from the lowest: compound 1; then compounds 3 and 2 (each within the scatter of the next).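

On an amide-type nitrogen whose other neighbours are: carbonyl carbon, putting 2-methylcyclopropyl in place of the group of 10 heavy atoms gives a number 1.10 log units higher from compound 1 to compound 3 (beyond the scatter) in this assay, with the rest of the structure unchanged. Among these compounds, this is the first reading of a change at this one place, and it shows that the exchange alone is enough to move the number by more than the scatter. By count, the group that leaves has 1 hydrogen-bond acceptor, 1 double bond outside aromatic rings and a five-membered non-aromatic ring with 1 hetero atom, while 2-methylcyclopropyl has none of these, and no measurement offers an account of which difference, if any, underlies the step.

A single step leaves open how the number follows the group at this nitrogen, as the whole group changes at once and the counted differences cannot be separated. Plain cyclopropyl, a longer chain or a group bearing an amine or a carboxylic acid at the same place would each give a further reading, and the size and direction of those steps remain open.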